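Pyridyl-to-phenyl swap on the hydrazide carbonyl

The source may hold more compounds than are shown below. What is called first, only, known or untested is meant among the compounds shown, and "the series" means these compounds.

Measured so far:
compound 1, `CCCc1n[nH]c2c(=O)n(NC(=O)c3ccncc3)c(-c3cccc(OC)c3)nc12`: 4.04%
compound 2, `COc1cccc(-c2nc3c(-c4ccc(C5CCNCC5)cc4)n[nH]c3c(=O)n2NC(=O)c2ccncc2)c1`: 18.2%

In a functional assay on SK-OV-3 cells (Homo sapiens) for cytotoxicity, read by sulforhodamine B assay, with a stated time of 2 days, tested at 100 uM (a lower number here means less inhibition, a higher number more inhibition at the concentration tested (going by the name of the read-out)), compound 1 gives 4.04%, the lowest of the two numbers; compound 2 sits nearest, and the change a number 14.2 percentage points higher from compound 1 to compound 2 (beyond the scatter) lies beyond the scatter. The new compound 3, `CCCc1n[nH]c2c(=O)n(NC(=O)c3ccccc3)c(-c3cccc(OC)c3)nc12`, differs from compound 1 in one place: phenyl in place of pyridin-4-yl on a carbonyl carbon.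

Among the compounds with values here, the only measured step changes the substituent on an aromatic carbon of the core, not the carbonyl carbon, so it does not speak to the present change; no step at the benzoyl position has been measured. With compound 1 as the sole anchor, the expectation for compound 3 is a step of a number 2 percentage points higher from compound 1 to compound 3 (within the scatter), within the scatter, with no reason from the data to expect a clear direction.

Compound 3 is accordingly estimated at 6%, within a range of 0% to 18%.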

Compound 3, a percentage reported as inhibition, at one concentration (the size of the read-out at that concentration, not a potency): 9.96%
For compound 3 the middle estimate is 4 percentage points below the measured one; the measured number falls inside the stated range.
By their numbers in this assay, from the lowest: compounds 1, 3 and 2 (each within the scatter of the next, the first and the last beyond it).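

Within the data shown here, this is the first step read at the carbonyl carbon: in this assay, phenyl in place of pyridin-4-yl gives a number 5.9 percentage points higher from compound 1 to compound 3 (within the scatter). The ring nitrogen of pyridin-4-yl, the hydrogen-bond acceptor that leaves with this change, can therefore be exchanged for carbon without a step beyond the scatter at this concentration. No available evidence bears on this result.

Still open, as far as these compounds go, is whether a piperidin-4-yl ring or a carboxylic acid-bearing phenyl on the carbonyl carbon would give a step beyond the scatter. From the compounds shown here alone, it is also open whether 4-(piperidin-4-yl)phenyl in place of propyl, which gives a number 14.2 percentage points higher from compound 1 to compound 2 (beyond the scatter) with the pyridin-4-yl group present, would give a comparable step with the benzamido group of compound 3.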